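From Methoxycarbonyl to Propargyloxy: One Number to Start From

A few compounds are considered here, and "the series" means these few. Any claim that something is new, unique, unknown or untested is made for them only; others in the source may bear on it.

- compound 1 `O=C(O)c1cc(N2C(=O)C3=C(CCCC3)C2=O)ccc1Cl` gives > 100000 nM (a limit)
- compound 2 `COC(=O)c1cc(N2C(=O)C3=C(CCCC3)C2=O)c(F)cc1Cl` gives 170 nM
- compound 3 `CC(C)(C)OC(=O)c1cc(N2C(=O)C3=C(CCCC3)C2=O)ccc1Cl` gives > 100000 nM (a limit)

Within the data shown here, in a functional assay on the whole organism with Scenedesmus acutus as the target, with a stated time of 20 h (a higher number here means a weaker inhibitor, a lower number a stronger inhibitor), compound 2 gives 170 nM, the only true number of the three. The results for compound 1 and compound 3 are limits.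

Compound 4 `C#CCOc1cc(N2C(=O)C3=C(CCCC3)C2=O)c(F)cc1Cl` has not been measured yet. It differs from compound 2 as follows: propargyloxy in place of methoxycarbonyl on an aromatic carbon. In short, propargyloxy stands in place of methoxycarbonyl on an aromatic carbon, ortho to a chloro group and para to a fluoro group.

Among the measured compounds shown here, the only measured step is a step that the two limits leave unreadable from compound 1 to compound 3, so it offers no size to carry over to this change. The expectation therefore starts from compound 2 at 170 nM, with only a slight lean towards a stronger inhibitor and a wide margin in either direction. The expected change is a 3.4-fold lower number from compound 2 to compound 4 (0.53 log units; beyond the scatter). For compound 4 the estimated value is 50 nM, with an expected range from 5 nM to 500 nM.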

Compound 4, half-maximal inhibitory concentration: 141 nM
Beside the measured number, compound 4's estimate is 2.8-fold (0.45 log units) below it; the range from low to high includes it.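

In this assay, propargyloxy in place of methoxycarbonyl gives a 1.2-fold lower number from compound 2 to compound 4 (0.08 log units; within the scatter), so on this aromatic carbon, ortho to a chloro group and para to a fluoro group, the two groups cannot be told apart. A group with a carbonyl and a group with a triple bond, each of 4 heavy atoms, thus serve equally well here, and the carbonyl is not required at this position in this pair. This is the only readable step, as the step between compound 1 and compound 3 cannot be read: the limit of > 100000 nM in this assay, at which 2 of the 4 values shown sit.

Going by these compounds, whether an amine or a longer chain on the same carbon would hold this level remains open. So does whether the match between these two groups would survive without the fluoro group.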